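The source may report more compounds than this note shows. Statements on the series, on what has been measured and on what is new or still open speak of the compounds shown alone.

Compound 1 `COc1ccccc1Oc1c(N)nc(-c2cccc(C)c2)nc1Cl`: 13100 nM
Compound 2 `COc1ccccc1Oc1c(N)nc(-c2ccc(I)cc2)nc1Cl`: 5400 nM
Compound 3 `COc1ccccc1Oc1c(N)nc(-c2cccc(C)c2)nc1OCCO`: 70900 nM

In a functional assay on B16 cells (Mus musculus) for cytotoxicity, read by CCK-8 assay, with a stated time of 24 h (on this read-out higher numbers stand for weaker inhibition and lower numbers for stronger inhibition), compound 3 stands highest of the three numbers; its nearest neighbour is compound 1 and its furthest is compound 2. The step to compound 4 `COc1ccccc1Oc1c(N)nc(-c2cccc(I)c2)nc1OCCO` is iodo in place of methyl on an aromatic carbon, the same change read one bond further out being 3-methylphenyl to 3-iodophenyl. Going by the values given here, one measured step bears on it: a 2.4-fold lower number from compound 1 to compound 2 (0.38 log units; beyond the scatter), where 4-iodophenyl replaced 3-methylphenyl. The two changes are not identical, so the guidance is loose, but a modest lower number in this assay is therefore expected. Compound 4 is expected to give 35000 nM, within a range of 12000 nM to 100000 nM. The step this estimate implies, a 2.0-fold lower number from compound 3 to compound 4 (0.31 log units; beyond the scatter), is an expectation and not a measurement.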

Compound 4, half-maximal inhibitory concentration: 20300 nM
The estimate for compound 4 lay 1.7-fold (0.24 log units) above the measured number; the range from low to high includes it.
By their numbers in this assay, from the lowest: compound 2; then compounds 1 and 4 (each within the scatter of the next); then compound 3.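

With the iodo group placed where the methyl stood and everything else held, this assay shows a 3.5-fold lower number from compound 3 to compound 4 (0.54 log units; beyond the scatter), a drop that is beyond the scatter. Going by these compounds alone, the earlier step from 3-methylphenyl to 4-iodophenyl changed the group's place as well, so this is the first reading of iodo in place of methyl alone, here in compounds carrying 2-hydroxyethoxy. No measurement at hand gives a reason for this drop. Still open, going by these compounds, is whether the same swap lowers the number when chloro replaces 2-hydroxyethoxy. Also open, on these data alone, is how bromo, an amine or a carboxylic acid would read on that same aromatic carbon.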